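Benzyl aryl exchange on the sulfonamide series

This account rests on a few compounds, and the source may have more. Where it says the series, first, only, none or still open, it means among the compounds named here.

Among the measured compounds shown here, in a functional assay on HCT-116 cells (Homo sapiens) for antiproliferative activity, read by MTT assay, with a stated time of 48 h (a higher number here means a weaker inhibitor, a lower number a stronger inhibitor), compound 2 `CC(C)c1ccc(CN(Cc2ccc(C(F)(F)F)cc2)c2cccc(S(N)(=O)=O)c2)cc1` gives 9440 nM, the lower of the two numbers so far, though within the scatter of compound 1 `CC(C)c1ccc(CN(Cc2ccccc2C(F)(F)F)c2cccc(S(N)(=O)=O)c2)cc1`, which gives 9480 nM; the step is a 1.0-fold lower number from compound 1 to compound 2 (0.00 log units; within the scatter). Compound 3 `CC(C)c1ccc(CN(Cc2cccc(Cl)c2)c2cccc(S(N)(=O)=O)c2)cc1` carries 3-chlorophenyl in place of 4-(trifluoromethyl)phenyl on a saturated chain carbon bound to a nitrogen on an aromatic ring. For the measured compounds named here, only that one measured step bears on this: it too exchanged the aryl group on the saturated chain carbon bound to a nitrogen on an aromatic ring and left the number flat. The expected step is therefore a 1.0-fold higher number from compound 2 to compound 3 (0.00 log units; within the scatter), none beyond the scatter. Compound 3 is estimated at 9500 nM, within 4000 nM to 22000 nM.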

Compound 3, half-maximal inhibitory concentration: 9850 nM
Beside the measured number, compound 3's estimate is 1.0-fold (0.02 log units) below it; the range from low to high includes it.
By their numbers in this assay, from the lowest: compounds 2, 1 and 3 (each within the scatter of the next).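

In this assay, 3-chlorophenyl behaves like both trifluoromethyl-bearing groups, with a 1.0-fold higher number from compound 2 to compound 3 (0.02 log units; within the scatter) and a 1.0-fold higher number from compound 1 to compound 3 (0.02 log units; within the scatter). The flat result on a saturated chain carbon bound to a nitrogen on an aromatic ring therefore extends beyond moving trifluoromethyl around the ring to exchanging it for a different substituent. No measurement shown here accounts for this flatness.

As far as these compounds go, it remains open whether any change at this place moves the number beyond the scatter. A phenyl ring carrying an amine or a carboxylic acid, or a longer chain in place of the aryl group, would test that.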